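A Benzyl Group on the Amine of Compound 1

The compounds below may be only part of what the source reports. "The series", "measured", "known", "first", "only" and "open" are said of these compounds alone.

Compound 1 `Cc1cc(N[C@H](CCCCN)C(=O)NO)cc(C)c1F` stands in a physicochemical assay for lipophilicity, at pH 7.4 (on this read-out higher numbers stand for higher lipophilicity and lower numbers for lower lipophilicity), only at a limit, as compound 1 gives < 3 and no number. Compound 2 `Cc1cc(S(=O)(=O)NCCCC[C@@H](Nc2cc(C)c(F)c(C)c2)C(=O)NO)ccc1F` also gives only a limit, < 3. Compound 3 `Cc1cc(CNCCCC[C@@H](Nc2cc(C)c(F)c(C)c2)C(=O)NO)ccc1F` gives a limit too, < 3. All three values therefore sit at the limit of < 3 in this assay, at which 3 of the 3 values shown sit.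

Compound 4 `Cc1ccc(CNCCCC[C@@H](Nc2cc(C)c(F)c(C)c2)C(=O)NO)cc1` carries one change from compound 1: 4-methylbenzyl in place of hydrogen on an amine nitrogen. Going by the values given here, the one measured step that bears on this places 4-fluoro-3-methylbenzyl in place of hydrogen on an amine nitrogen, and it is a step that the two limits leave unreadable from compound 1 to compound 3. That step gives neither a size nor a direction to carry over, so any expectation here is loose. The expected change is a step that the limit leaves unreadable from compound 1 to compound 4, an estimate with no firm measured anchor. For compound 4 the estimated value in this assay is 2.4, with an expected range from 1.6 to 3.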

Compound 4, distribution coefficient: < 3
Compound 4: only a limit was reported; the forecaster's own chance of this, stated with the estimate: 75%; the middle value is on the limit's open side.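

In this assay compound 4 gives < 3, which is a limit and not a number. No step from compound 1 or compound 3 to compound 4 can be read: the limit of < 3 in this assay, at which 4 of the 4 values shown sit.

The compounds shown leave open where any of these four compounds truly lies in this assay, and whether 4-methylbenzyl and 4-fluoro-3-methylbenzyl differ there at all.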